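From compound 2 to compound 4: losing trifluoromethyl

This account rests on a few compounds, and the source may have more. Where it says the series, first, only, none or still open, it means among the compounds named here.

In an ADME assay on Vero 76 cells (Chlorocebus sabaeus) for cytotoxicity, read by MTT assay, with a stated time of 96 h (a higher number here means that more compound is tolerated, a lower number that less compound is tolerated), compound 2 `Cc1ccc(NCc2cn(-c3ccccc3)nc2-c2ccc(C(F)(F)F)cc2)cc1` gives 82000 nM, the highest of the two numbers in this small set. Compound 3 `FC(F)(F)c1ccc(NCc2cn(-c3ccccc3)nc2-c2ccc(C(F)(F)F)cc2)cc1` gives 26000 nM. Compound 1 `Cc1ccc(NCc2cn(-c3ccccc3)nc2-c2ccc(Cl)cc2)cc1` gives > 100000 nM, which is a limit of the assay and not a number.

Compound 4 `Cc1ccc(NCc2cn(-c3ccccc3)nc2-c2ccccc2)cc1` differs from compound 2 by hydrogen in place of trifluoromethyl on an aromatic carbon, para to a large group: hydrogen in place of trifluoromethyl on an aromatic carbon.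

Going by the values given here, two measured steps bear on this change. The closer one is an at least 1.2-fold lower number from compound 1 to compound 2 (0.08 log units; that floor lies within the scatter), made at the same place as the change to compound 4. The other is a 3.2-fold lower number from compound 2 to compound 3 (0.50 log units; beyond the scatter), which is beyond the scatter but is made at a different place, so it carries less weight here. Neither step tests hydrogen directly.

The nearest evidence therefore points to little change when trifluoromethyl leaves. The expected 1.2-fold higher number from compound 2 to compound 4 (0.09 log units; within the scatter) is small, towards a higher number, and not beyond the scatter. Compound 4 may also end at the limit of > 100000 nM in this assay, at which 1 of the 3 values shown sits. For compound 4 the estimated value is 100000 nM, with an expected range of 55000 nM to 180000 nM.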

Compound 4, half-maximal cytotoxic concentration: > 100000 nM
Compound 4: only a limit was reported; the forecaster's own chance of this, stated with the estimate: 55%; the middle value lies on the limit itself.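

Across this position, on an aromatic carbon para to a large group, hydrogen in place of trifluoromethyl in this assay gives an at least 1.2-fold higher number from compound 2 to compound 4 (0.08 log units; that floor lies within the scatter), so the change from 4-(trifluoromethyl)phenyl to phenyl has no readable effect beyond the scatter. Compound 4 gives > 100000 nM, which is a limit of the assay and not a number. The hydrogen of compound 4 and the chloro of compound 1 both end at that limit, so the step between those two compounds cannot be read, and the three groups shown at this position give no step beyond the scatter, with the top of the range now reached twice: the limit of > 100000 nM in this assay, at which 2 of the 4 values shown sit.

Going by these compounds alone, the only step beyond the scatter remains a 3.2-fold lower number from compound 2 to compound 3 (0.50 log units; beyond the scatter), made at a different place, so whether any group at the position para to a large group can lower the number as far is still open. As far as these compounds go, how a carboxylic acid or an amine on this aromatic carbon would read in this assay, and how far compound 1 and compound 4 really lie past the limit, also stay open.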